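This account rests on a few compounds, and the source may have more. Where it says the series, first, only, none or still open, it means among the compounds named here.

Compound 1 `CNC(=O)[C@@]12C[C@@H]1[C@@H](n1cnc3c(NC)nc(C#Cc4ccc(CO)cc4)nc31)[C@H](O)[C@@H]2O` is the reference point here. Among the measured compounds shown here, in an assay on CHO cells for displacement of a labelled ligand from adenosine receptor A3 (Homo sapiens), read by scintillation counting, with a stated time of 60 min (a higher number here means a weaker inhibitor, a lower number a stronger inhibitor), compound 1 gives 2.16 nM, which is the highest of the three numbers measured so far, although every neighbour sits within the usual scatter of it. Compound 2 `CNC(=O)[C@@]12C[C@@H]1[C@@H](n1cnc3c(NC)nc(C#Cc4cc(C)c(C)o4)nc31)[C@H](O)[C@@H]2O` gives 1.45 nM, and compound 3 `CCc1ccc(C#Cc2nc(NC)c3ncn([C@H]4[C@H](O)[C@H](O)[C@]5(C(=O)NC)C[C@H]45)c3n2)o1` gives 1.5 nM. The two measured steps that start from compound 1 are a 1.5-fold lower number from compound 1 to compound 2 (0.17 log units; within the scatter) and a 1.4-fold lower number from compound 1 to compound 3 (0.16 log units; within the scatter); the step between the other two is a 1.0-fold higher number from compound 2 to compound 3 (0.01 log units; within the scatter). All three steps swap the aromatic group on the triple-bonded carbon and none of them moves the number beyond the scatter.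

Compound 4 `CNC(=O)[C@@]12C[C@@H]1[C@@H](n1cnc3c(NC)nc(C#Cc4ccsc4)nc31)[C@H](O)[C@@H]2O` has not yet been measured. It differs from compound 1 by thiophen-3-yl in place of 4-(hydroxymethyl)phenyl on a triple-bonded carbon. This is again a swap of the aromatic group on the triple-bonded carbon, the same kind of change seen from compound 1 to compound 2 and from compound 1 to compound 3, where the numbers barely moved. Because those steps were a 1.5-fold lower number from compound 1 to compound 2 (0.17 log units; within the scatter) and a 1.4-fold lower number from compound 1 to compound 3 (0.16 log units; within the scatter), compound 4 is expected to stay close to compound 1, with no step beyond the scatter in this assay. The expected step is a 1.1-fold lower number from compound 1 to compound 4 (0.06 log units; within the scatter). The estimate for compound 4 in this assay is 1.9 nM, within a range from 0.7 nM to 5 nM.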

Compound 4, inhibition constant: 0.52 nM
The estimate for compound 4 lay 3.7-fold (0.56 log units) above the measured number; measured number outside the range, below it.
By their numbers in this assay, from the lowest: compound 4; then compounds 2, 3 and 1 (each within the scatter of the next).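

In this assay the group on the triple-bonded carbon proves able to move the number: thiophen-3-yl gives a 4.2-fold lower number from compound 1 to compound 4 (0.62 log units; beyond the scatter) and a 2.9-fold lower number from compound 3 to compound 4 (0.46 log units; beyond the scatter) and a 2.8-fold lower number from compound 2 to compound 4 (0.45 log units; beyond the scatter), each modest but beyond the scatter, whereas swaps among the earlier groups stayed within it. Compound 4 is therefore the strongest inhibitor of the four, and the flat picture holds only among 4-(hydroxymethyl)phenyl, 4,5-dimethylfuran-2-yl and 5-ethylfuran-2-yl, not for every aromatic ring at this place. Thiophen-3-yl differs from 4-(hydroxymethyl)phenyl in ring size, in carrying sulfur and in lacking the hydroxymethyl, and no supporting data separate these differences or explain the result.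

The compounds shown leave open whether the thiophene ring must be joined through its 3-position, as thiophen-2-yl would test, and whether a methyl or ethyl group on that ring keeps the number this low. They also leave open what a group without an aromatic ring, such as cyclopropyl or a longer alkyl chain, or a ring carrying an amine or a carboxylic acid, would do at this place.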